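Cytotoxicity of a thiazole series: carbamate to benzamide

This account rests on a few compounds, and the source may have more. Where it says the series, first, only, none or still open, it means among the compounds named here.

Compound 1, `O=C(CCCCC(=O)Nc1ncc(Cc2ccc(F)cc2)s1)Nc1ncc(Cc2ccc(F)cc2)s1`, gives > 50000 nM in an ADME assay on HepG2 2.2.15 cells (Homo sapiens) for cytotoxicity (on this read-out lower numbers stand for higher toxicity in this test and higher numbers for lower toxicity in this test), which is a limit of the assay.
Compound 2, `CC(C)(C)OC(=O)Nc1ncc(C(Oc2ccc(F)c(Cl)c2)c2ccc(Cl)cc2)s1`, gives > 50000 nM in this assay, again a limit.
Compound 3, `CC(C)(C)OC(=O)Nc1ncc(C(Oc2ccc3cc(Br)ccc3c2)c2ccc(Cl)cc2)s1`, gives > 50000 nM in this assay, also a limit.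

Compound 3 therefore stands only at a limit in this assay, and the two other values shown are limits as well, so the limit of > 50000 nM in this assay, at which 3 of the 3 values shown sit, holds for every compound measured. Among the measured compounds shown here, the one step between measured compounds, a step that the two limits leave unreadable from compound 2 to compound 3, is therefore unreadable in size and concerns a different part of the molecule than the change now considered.

Compound 4, `O=C(Nc1ncc(C(Oc2ccc3cc(Br)ccc3c2)c2ccc(Cl)cc2)s1)c1ccccc1`, differs from compound 3 in one place: phenyl in place of tert-butoxy on a carbonyl carbon. For the measured compounds named here, no measured step bears readably on this change, so no step beyond the scatter is expected in this assay, in either direction. The step of a number no higher from compound 3 to compound 4 (the limit leaves the size open) is expected to be no more than the scatter. Compound 4 is estimated at 50000 nM in this assay, with a range from 20000 nM to 120000 nM, and most probably again a limit.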

Compound 4, half-maximal cytotoxic concentration: "not toxic" (no number reported)
No number was reported for compound 4, so the estimate cannot be set against anything.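

No new step can be read between compound 3 and compound 4, since compound 4 is reported in this assay only as not toxic, without a number. The compounds shown leave open at what concentration, if any, toxicity would appear in this assay, with the values so far resting on: the limit of > 50000 nM in this assay, at which 3 of the 4 values shown sit.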